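The source may hold more compounds than are shown below. What is called first, only, known or untested is meant among the compounds shown, and "the series" means these compounds.

Working notes on the series. Compound 1 `CCC1C(=O)N(C)c2cnc(Nc3ccc(S(=O)(=O)NCC(C)C)cc3)nc2N1c1ccn(C)n1` and compound 2 `CCCNS(=O)(=O)c1ccc(Nc2ncc3c(n2)N(c2ccn(C)n2)C(CC)C(=O)N3C)cc1` share one core; compound 3 `CCCCNS(=O)(=O)c1ccc(Nc2ncc3c(n2)N(C2CCCC2)[C@H](CC)C(=O)N3C)cc1` and compound 4 `CCCNS(=O)(=O)c1ccc(Nc2ncc3c(n2)N(C2CCCC2)[C@H](CC)C(=O)N3C)cc1` share another. In a functional assay on NCI-H1975 cells (Homo sapiens) for antiproliferative activity, read by CCK-8 assay, with a stated time of 72 h (a lower number here means a stronger inhibitor of growth, a higher number a weaker inhibitor of growth), compound 1 gives 15000 nM. Compound 2 gives 21700 nM in this assay. The difference between them is hydrogen in place of methyl on a saturated chain carbon bound to two saturated chain carbons, and it made a 1.4-fold higher number from compound 1 to compound 2 (0.16 log units; within the scatter). Compound 3 gives 1610 nM in this assay, the lowest of the three measured numbers, beyond the scatter from both compound 1 and compound 2; how the core of compound 3 differs from that of compound 1 is not broken down here. Compound 4 has not been measured. The change from compound 3 to compound 4 is hydrogen in place of methyl on a saturated chain carbon, three bonds along the chain from a sulfonamide nitrogen. Among the measured compounds shown here, this is the same kind of change as the one from compound 1 to compound 2, though the place is not identical: there the carbon is bound to two saturated chain carbons, here it sits three bonds along the chain from a sulfonamide nitrogen. Because a 1.4-fold higher number from compound 1 to compound 2 (0.16 log units; within the scatter) stayed within the scatter, a comparably small step of a 1.2-fold higher number from compound 3 to compound 4 (0.09 log units; within the scatter) is expected in this assay. Compound 4 is accordingly estimated at 2000 nM, with a likely range from 1000 nM to 4500 nM.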

Compound 4, concentration for 50% growth inhibition: 2100 nM
Compound 4: the middle estimate sits 1.1-fold (0.02 log units) below what was measured; the measured number falls inside the stated range.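

In this assay, hydrogen in place of methyl on a saturated chain carbon, three bonds along the chain from a sulfonamide nitrogen, gave a 1.3-fold higher number from compound 3 to compound 4 (0.12 log units; within the scatter). Set beside the earlier step, the change has the same small size on both cores: the same change on two cores in this assay, a 1.4-fold higher number (0.16 log units; within the scatter) from compound 1 to compound 2 and a 1.3-fold higher number (0.12 log units; within the scatter) from compound 3 to compound 4, 1.1-fold (0.04 log units) apart, within the scatter of two such steps

Among the compounds shown here, this shows only that shortening the chain on the sulfonamide nitrogen by one carbon left no step beyond the scatter on either core; it does not show that a real effect of fixed size carries from one core to the other, since neither step can be told from the scatter, the two changes do not sit at an identical place, and only two cores are represented.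

The compounds shown leave open whether a longer chain, a cyclopropyl ring, an amine or a carboxylic acid in place of these chains on the sulfonamide nitrogen would give a step beyond the scatter. Also open, on these data alone, is whether any such step would have the same size on both cores.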